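The source may hold more compounds than are shown below. What is called first, only, known or untested is meant among the compounds shown, and "the series" means these compounds.

Within the data shown here, in an ADME assay on CCRF-HSB-2 cells (Homo sapiens) for cytotoxicity, with a stated time of 7 days (a lower number here means that less compound is tolerated, a higher number that more compound is tolerated), compound 2 `CCCCCCSc1nc(N)nc2c1ncn2/C=C1/CC1(CO)CO` gives 60000 nM, the only number available for the series so far. Compound 1 `CNc1nc(N)nc2c1ncn2/C=C1/CC1(CO)CO` reads > 20000 nM in this assay, and this is a limit, not a number. The next compound is compound 3 `CCCOc1nc(N)nc2c1ncn2/C=C1/CC1(CO)CO`, reached from compound 2 by propoxy in place of hexylsulfanyl on an aromatic carbon, with the rest of the structure unchanged.

Among the measured compounds shown here, only one measured step bears on this change: a step that the limit leaves unreadable from compound 1 to compound 2. For the measured compounds named here, it also swaps the group on that aromatic carbon, but the only evidence on its size is the limit of > 20000 nM in this assay, at which 1 of the 2 values shown sits. The series therefore gives no measured size for a swap at this carbon, and no direction either. With nothing to carry over, no shift beyond the scatter is expected in this assay, although the uncertainty stays wide on both sides. The expected change is a 1.2-fold lower number from compound 2 to compound 3 (0.08 log units; within the scatter). For compound 3 the estimated value is 50000 nM, with an expected range from 18000 nM to 120000 nM. A report as a limit rather than a number would not be surprising.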

Compound 3, half-maximal cytotoxic concentration: > 20000 nM
Compound 3: no number, only a limit (the forecaster's own chance of this, stated with the estimate: 45%); the middle value is on the limit's open side.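

In this assay compound 3 reads > 20000 nM, a limit and not a number. Among these compounds, no step among compound 1, compound 2 and compound 3 can be read: the limit of > 20000 nM in this assay, at which 2 of the 3 values shown sit. The compounds shown leave open how large any difference between methylamino, hexylsulfanyl and propoxy on this aromatic carbon is, and in which direction it runs.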